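A few compounds are considered here, and "the series" means these few. Any claim that something is new, unique, unknown or untested is made for them only; others in the source may bear on it.

Compound 1 `COc1ccccc1CN1CCC=C(CCC(=O)NO)C1=O`: > 10000 nM (a limit)
Compound 2 `Cc1ccc(S(=O)(=O)Nc2ccc(CN3CCC=C(CCC(=O)NO)C3=O)cc2)cc1`: > 10000 nM (a limit)
Compound 3 `O=C(CCC1=CCCN(CCCCc2cccc3ccccc23)C1=O)NO`: 1670 nM

All three compounds were tested in a functional assay on HCT-15 cells (Homo sapiens) for inhibition, read by sulforhodamine B assay; on this read-out lower numbers stand for stronger inhibition of growth and higher numbers for weaker inhibition of growth. Compound 1 gives no number, only a limit: it sits at the limit of > 10000 nM in this assay, at which 2 of the 3 values shown sit. Compound 4 `Cc1ccccc1CN1CCC=C(CCC(=O)NO)C1=O` has methyl in place of methoxy on an aromatic carbon, ortho to a large group: methyl in place of methoxy on an aromatic carbon. Within the data shown here, no pair of measured compounds tests this exchange, and no step beyond the usual scatter is expected in this assay. This expectation rests on the limit of compound 1, > 10000 nM. The expected step is a step that the limit leaves unreadable from compound 1 to compound 4. Compound 4 is estimated at 12000 nM, with an expected range of 5000 nM to 30000 nM, and it may well return only a limit.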

Compound 4, concentration for 50% growth inhibition: > 10000 nM
Compound 4 was reported as a limit (the forecaster's own chance of this, stated with the estimate: 70%); the middle value is on the limit's open side.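

No step can be read from compound 1 to compound 4, as both are reported only as limits: the limit of > 10000 nM in this assay, at which 3 of the 4 values shown sit.

The compounds shown leave open whether methyl and methoxy differ in their effect on growth inhibition on this shared core.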